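Compound 4: Chloro to Trifluoromethyl, Tolerance Expected Unchanged

The compounds below may be only part of what the source reports. "The series", "measured", "known", "first", "only" and "open" are said of these compounds alone.

Compound 1 is `CC(=O)c1ccc2[nH]c(-c3ccc(Cl)cc3)nc2c1`. In an ADME assay on BHK-21 cells (Mesocricetus auratus) for cytotoxicity, read by MTT assay (a higher number here means that more compound is tolerated, a lower number that less compound is tolerated), compound 1 gives > 100000 nM, which is a limit of the assay and not a number.
Compound 2 is `CC(=O)c1ccc2[nH]c(-c3ccc(C(F)(F)F)cc3)nc2c1`. In this assay compound 2 gives > 100000 nM, again only a limit.
Compound 3 is `C/C(=N\NC(N)=O)c1ccc2[nH]c(-c3ccc(Cl)cc3)nc2c1`. In this assay compound 3 gives > 100000 nM, once more a limit.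

The three measured compounds share one core. Compound 2 differs from compound 1 in a single place: trifluoromethyl in place of chloro on an aromatic carbon. In this assay this gives a step that the two limits leave unreadable from compound 1 to compound 2. Compound 3 differs from compound 1 in one other place: a group of 7 heavy atoms (3 carbon, 3 nitrogen, 1 oxygen; no ring) in place of a group of 3 heavy atoms (2 carbon, 1 oxygen; no ring), on an aromatic carbon. In this assay this gives a step that the two limits leave unreadable from compound 1 to compound 3. Both steps are unreadable because the limit of > 100000 nM in this assay, at which 3 of the 3 values shown sit, leaves no number on either side of them.

Compound 4, `C/C(=N\NC(N)=O)c1ccc2[nH]c(-c3ccc(C(F)(F)F)cc3)nc2c1`, has not been measured. It differs from compound 3 by trifluoromethyl in place of chloro on an aromatic carbon. This is the same change that leads from compound 1 to compound 2, made on the core of compound 3 rather than that of compound 1; how the two cores differ has been described above in the change from compound 1 to compound 3.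

The step from compound 3 to compound 4 is expected to be a step that the limit leaves unreadable from compound 3 to compound 4, an expectation that rests on (the limit of > 100000 nM in this assay, at which 3 of the 3 values shown sit), at which every measured compound sits, and on a step that the two limits leave unreadable from compound 1 to compound 2. Compound 4 is therefore expected to give about 150000 nM, most plausibly between 70000 nM and 400000 nM, and most likely to be reported only as a limit once more.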

Compound 4, half-maximal cytotoxic concentration: > 100000 nM
Compound 4 gave a limit, no number; the forecaster's own chance of this, stated with the estimate: 85%; the middle value does not contradict the limit.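

In this assay compound 4 gives > 100000 nM, which is a limit and not a number. For the compounds shown here, the steps from compound 3 and from compound 2 to compound 4 cannot be read, because no compound here has a number to compare: the limit of > 100000 nM in this assay, at which 4 of the 4 values shown sit. The compounds shown leave open how much of each compound is tolerated, and whether either change in structure alters that tolerance at all.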